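This account rests on a few compounds, and the source may have more. Where it says the series, first, only, none or still open, it means among the compounds named here.

Compound 2 `CC(C)Cc1nc(/N=N/N(C)C)c(C(N)=O)[nH]1` gives 3.53 in a functional assay on L1210 cells (Mus musculus) for antiproliferative activity (on this read-out higher numbers stand for higher potency (the scale is a negative logarithm) and lower numbers for lower potency), the higher of the two measured numbers; compound 1 `CN(C)/N=N/c1nc(Cc2ccccc2)[nH]c1C(N)=O` gives 2.89 in this assay, and the step of a number 0.64 log units higher from compound 1 to compound 2 (beyond the scatter) is the only one measured so far. Compound 3 `CCCc1nc(/N=N/N(C)C)c(C(N)=O)[nH]1` differs from compound 2 by hydrogen in place of methyl on a saturated chain carbon bound to two saturated chain carbons. Going by the values given here, no measured step shortens a chain of this kind, so the one measured step offers no direct guide. The step of a number 0.13 log units lower from compound 2 to compound 3 (within the scatter) is therefore expected to stay within the scatter. Compound 3 is estimated at 3.4, ranging from 2.9 to 3.9.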

Compound 3, logarithm of the reciprocal of the active concentration, log(1/C): 3.42
Estimate against measurement, compound 3: 0.02 log units below, within the range that was stated.
By their numbers in this assay, from the lowest: compound 1; then compounds 3 and 2 (each within the scatter of the next).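

In this assay the change from isobutyl to propyl gives a number 0.11 log units lower from compound 2 to compound 3 (within the scatter) and so shows that, at this position, hydrogen in place of methyl on a saturated chain carbon bound to two saturated chain carbons moves the number no further than the scatter. Ethyl in place of phenyl gives a number 0.53 log units higher from compound 1 to compound 3 (beyond the scatter) and stands beside the isopropyl step as a second replacement of phenyl beyond the scatter. Nothing measured here explains these numbers.

The compounds shown leave open how a longer chain such as pentyl, or an amine or a carboxylic acid at the end of the chain, would read in this assay.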